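A Chloro-to-Hydrogen Swap Repeated on a Second Core

The compounds below may be only part of what the source reports. "The series", "measured", "known", "first", "only" and "open" are said of these compounds alone.

Compound 3 `ClCc1ccccc1Cn1cnc2nc(Cl)nc(Cl)c21` and compound 2 `ClCc1ccccc1Cn1cnc2ncnc(Cl)c21` differ in one place: hydrogen in place of chloro on an aromatic carbon. In a functional assay on A498 cells (Homo sapiens) for cytotoxicity, read by sulforhodamine B assay, with a stated time of 48 h (a lower number here means a stronger inhibitor of growth, a higher number a weaker inhibitor of growth), compound 3 gives 5880 nM, while compound 2 gives 33100 nM, so that a 5.6-fold higher number from compound 3 to compound 2 (0.75 log units; beyond the scatter). Compound 1 `ClCc1ccc(Cn2cnc3nc(Cl)nc(Cl)c32)cc1` carries the same atoms joined differently; the difference between compound 1 and compound 3 is not broken down here. In this assay compound 1 gives 23400 nM. Compound 4 `ClCc1ccc(Cn2cnc3ncnc(Cl)c32)cc1` is related to compound 1 by the same change, (hydrogen in place of chloro on an aromatic carbon). The measured precedent is a 5.6-fold higher number from compound 3 to compound 2 (0.75 log units; beyond the scatter), and compound 1 starts from 23400 nM. Compound 4 is therefore expected to be a weaker inhibitor of growth, with an estimated step of a 3.8-fold higher number from compound 1 to compound 4 (0.59 log units; beyond the scatter). The estimate for compound 4 is 90000 nM, expected to lie between 35000 nM and 250000 nM.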

Compound 4, concentration for total growth inhibition: 3380 nM
For compound 4 the middle estimate is 27-fold (1.43 log units) above the measured one; the measured number lies below the stated range.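

On the core of compound 1, hydrogen in place of chloro on an aromatic carbon gives a 6.9-fold lower number from compound 1 to compound 4 (0.84 log units; beyond the scatter) in this assay and so runs opposite to the earlier step. Set side by side, the two steps show that the change does not carry from one core to the other in this series: the same change on two cores in this assay, a 5.6-fold higher number (0.75 log units; beyond the scatter) from compound 3 to compound 2 and a 6.9-fold lower number (0.84 log units; beyond the scatter) from compound 1 to compound 4, 39-fold (1.59 log units) apart, beyond the scatter of two such steps. With only these two pairs, the data do not show which structural difference between the cores sets the direction of the step.

The compounds shown leave open whether another group on that aromatic carbon, such as an amine or a methoxy group, would follow either step. They also leave open how either pair would respond if a hydroxymethyl group replaced the chloromethyl group.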